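Replacing 4-methoxyphenyl with 2-bromophenyl in compound 3

This account rests on a few compounds, and the source may have more. Where it says the series, first, only, none or still open, it means among the compounds named here.

Measured so far in a functional assay on HeLa cells (Homo sapiens) for cytotoxicity, read by sulforhodamine B assay; on this read-out higher numbers stand for weaker inhibition and lower numbers for stronger inhibition:
compound 1 `COc1ccc(S(=O)(=O)NC(C2=CC(=O)c3c(O)ccc(O)c3C2=O)C(C)C)cc1`: 8950 nM
compound 2 `CC(=O)c1ccc(S(=O)(=O)NC(C2=CC(=O)c3c(O)ccc(O)c3C2=O)C(C)C)cc1`: 3820 nM
compound 3 `COc1ccc(S(=O)(=O)NC(C)C2=CC(=O)c3c(O)ccc(O)c3C2=O)cc1`: 3760 nM

Compound 3 shares the low end of these three numbers with compound 2, and the two lie within the scatter of each other. The remaining gap is a 2.4-fold lower number from compound 1 to compound 3 (0.38 log units; beyond the scatter).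

Compound 4 `CC(NS(=O)(=O)c1ccccc1Br)C1=CC(=O)c2c(O)ccc(O)c2C1=O` has not yet been measured in this assay. It differs from compound 3 in one place, with 2-bromophenyl in place of 4-methoxyphenyl on a sulfonyl sulfur.

Within the data shown here, only one measured step alters this part of the structure. That step is a 2.3-fold lower number from compound 1 to compound 2 (0.37 log units; beyond the scatter), with acetyl in place of methoxy on an aromatic carbon, and it was modest. The change from isopropyl to methyl lies elsewhere in the structure and does not bear on this comparison. Among the measured compounds shown here, no measured compound carries bromine or shows a whole group exchanged on the sulfonyl sulfur, so the data set no firm direction. A small step, likely within the scatter, is therefore expected. The expected change is a 1.3-fold lower number from compound 3 to compound 4 (0.10 log units; within the scatter). Compound 4 is estimated at 3000 nM, with an expected range from 1200 nM to 7500 nM.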

Compound 4, half-maximal inhibitory concentration: 6200 nM
Compound 4: middle estimate off by 2.1-fold (0.32 log units), on the low side, within the range that was stated.
By their numbers in this assay, from the lowest: compounds 3, 2, 4 and 1 (each within the scatter of the next, the first and the last beyond it).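

In this assay, the exchange on the sulfonyl sulfur gives a 1.6-fold higher number from compound 3 to compound 4 (0.22 log units; within the scatter) and so stays within the scatter. Until now this part of the structure had been touched only through acetyl in place of methoxy, with the isopropyl chain present; here the whole 4-methoxyphenyl leaves on the methyl-bearing chain and 2-bromophenyl enters, so the methoxy is lost and bromine is brought in without a step beyond the scatter. No measurement on these compounds accounts for this outcome, so the result describes the size of the step and gives no reason for it.

Open, as far as these compounds go, is whether 4-bromophenyl would give a step like this one, which would separate the effect of bromine itself from that of where it stands on the ring. Also open, from the compounds shown here alone, is how the sulfonyl sulfur would respond to a pyridine ring, an aminophenyl group or a carboxylic acid on the aromatic ring, and whether 2-bromophenyl would behave the same way with the isopropyl chain in place of the methyl.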